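Lengthening the hydroxamic chain at the assay limit

The source may report more compounds than this note shows. Statements on the series, on what has been measured and on what is new or still open speak of the compounds shown alone.

Compound 1 `O=C(CCCC(=O)Nc1ccc(NC(=O)Nc2ccc(Cl)c(C(F)(F)F)c2)cc1)NO`: > 10000 nM
Compound 2 `O=C(CCCCCC(=O)Nc1ccc(NC(=O)Nc2ccc(Cl)c(C(F)(F)F)c2)cc1)NO`: > 10000 nM

In a functional assay on SK-HEP1 cells (Homo sapiens) for inhibition, read by sulforhodamine B assay, with a stated time of 48 h (on this read-out lower numbers stand for stronger inhibition and higher numbers for weaker inhibition), compound 2 gives > 10000 nM, which is a limit of the assay and not a number. Compound 1 gives > 10000 nM, which is also a limit. Neither compound has a measured potency, and the picture so far is simply (the limit of > 10000 nM in this assay, at which 2 of the 2 values shown sit).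

Compound 3 `O=C(CCCCCCC(=O)Nc1ccc(NC(=O)Nc2ccc(Cl)c(C(F)(F)F)c2)cc1)NO` keeps the shared core and changes one thing: (hydroxycarbamoyl)methyl in place of hydroxycarbamoyl on a saturated chain carbon, five bonds along the chain from a carbonyl carbon. Here (hydroxycarbamoyl)methyl takes the place of hydroxycarbamoyl on a saturated chain carbon, five bonds along the chain from a carbonyl carbon, so the chain grows longer.

Among the measured compounds shown here, the one measured step that bears on this, a step that the two limits leave unreadable from compound 1 to compound 2, also lengthened the chain, but it gives neither a size nor a direction to carry forward. No clear step is therefore expected in this assay, though a readable number remains possible. The estimated step is a number no higher from compound 2 to compound 3 (the limit leaves the size open). The estimate for compound 3 is 10000 nM, with an expected range from 3000 nM to 30000 nM.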

Compound 3, half-maximal inhibitory concentration: 8100 nM
The estimate for compound 3 lay 1.2-fold (0.09 log units) above the measured number, and the stated range covers the measured number.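

In this assay, among the compounds shown here, compound 3 gives 8100 nM, the only value in this short series that is a real reading and not a limit. Lengthening the chain at the saturated carbon therefore gives an at least 1.2-fold lower number from compound 2 to compound 3 (0.09 log units; that floor lies within the scatter) and an at least 1.2-fold lower number from compound 1 to compound 3 (0.09 log units; that floor lies within the scatter); both are only floors, set by the limits of the shorter chains, so the true size of each step remains unknown and could be larger. The step between the two shorter chains cannot be read at all, and the series shows only that the chain of compound 3 brings a reading into the measurable range, with the other two compounds still at the limit: the limit of > 10000 nM in this assay, at which 2 of the 3 values shown sit.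

From the compounds shown here alone, what remains open is whether a longer chain, such as one ending in 4-(hydroxycarbamoyl)butyl, would carry the number clearly beyond the scatter or whether the reading would stay close to that of compound 3. Going by these compounds, it is also open whether the hydroxycarbamoyl group itself is needed for this reading, which a carboxylic acid at the same chain end would test.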